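The source may hold more compounds than are shown below. What is called first, only, known or untested is meant among the compounds shown, and "the series" means these compounds.

In a functional assay on HEL cells (Homo sapiens) (on this read-out lower numbers stand for higher toxicity in this test and higher numbers for lower toxicity in this test), compound 1 `COC(=O)NC1=CS(=O)(=O)O[C@@]12[C@@H](CO[Si](C)(C)C(C)(C)C)O[C@@H](n1cc(C)c(=O)n(C)c1=O)[C@@H]2O[Si](C)(C)C(C)(C)C` gives > 200000 nM, which is a limit of the assay. Among the measured compounds shown here, compound 2 `Cc1cn([C@@H]2O[C@H](CO[Si](C)(C)C(C)(C)C)[C@@]3(OS(=O)(=O)C=C3NCCC(=O)OCc3ccccc3)[C@H]2O[Si](C)(C)C(C)(C)C)c(=O)n(C)c1=O` gives 200000 nM, the only actual number so far. Moving to compound 3 `CCNC(=O)NC1=CS(=O)(=O)O[C@@]12[C@@H](CO[Si](C)(C)C(C)(C)C)O[C@@H](n1cc(C)c(=O)n(C)c1=O)[C@@H]2O[Si](C)(C)C(C)(C)C` brings (ethylcarbamoyl in place of 2-(benzyloxycarbonyl)ethyl on an amine nitrogen), ethylcarbamoyl in place of 2-(benzyloxycarbonyl)ethyl on an amine nitrogen. For the measured compounds named here, the one measured step, a number no higher from compound 1 to compound 2 (the limit leaves the size open), has no readable size, and the evidence stops at the limit of > 200000 nM in this assay, at which 1 of the 2 values shown sits. With compound 2 at 200000 nM, no step beyond the scatter is expected. The estimated step is a 1.1-fold lower number from compound 2 to compound 3 (0.05 log units; within the scatter). For compound 3 the estimate is 180000 nM, with an expected range of 90000 nM to 200000 nM.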

Compound 3, half-maximal cytotoxic concentration: 10000 nM
Beside the measured number, compound 3's estimate is 18-fold (1.26 log units) above it; measured number outside the range, below it.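

Among the compounds shown here, compound 3 gives the first readable change at this amine nitrogen in this assay, where the number falls and toxicity in this test rises: ethylcarbamoyl in place of 2-(benzyloxycarbonyl)ethyl gives a 20-fold lower number from compound 2 to compound 3 (1.30 log units; beyond the scatter). Ethylamino in place of methoxy on a carbonyl carbon gives an at least 20-fold lower number from compound 1 to compound 3 (1.30 log units; beyond the scatter), so a large change also follows from this single swap on the carbonyl. That second step starts from compound 1, whose value is a limit: the limit of > 200000 nM in this assay, at which 1 of the 3 values shown sits.

Open, as far as these compounds go, is whether a longer chain, a free amine or a carboxylic acid in place of ethylcarbamoyl on the amine nitrogen would keep the lower number.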